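A few compounds are considered here, and "the series" means these few. Any claim that something is new, unique, unknown or untested is made for them only; others in the source may bear on it.

Compound 2, `C=CCc1cc(-c2ccc(O)c(CC=C)c2)c(O)c(C(c2ccc(Cl)cc2)N2CCCCC2)c1`, and compound 1, `C=CCc1cc(-c2ccc(O)c(CC=C)c2)c(O)c(C(c2cc(OC)c(OC)c(OC)c2)N2CCCCC2)c1`, share one core and differ only in the aryl group on the saturated chain carbon. In an assay on isolated protein for inhibition of Maltase-glucoamylase (Homo sapiens), with stated times of 15 min and 10 min, tested at 64 uM (a lower number here means less inhibition, a higher number more inhibition at the concentration tested (going by the name of the read-out)), compound 1 gives 56.4%, while compound 2 gives 45%, the lower of the two numbers. For the measured compounds named here, that change, a number 11.4 percentage points lower from compound 1 to compound 2 (beyond the scatter), is the only measured step, and it describes the swap of 3,4,5-trimethoxyphenyl for 4-chlorophenyl. Compound 3, `C=CCc1cc(-c2ccc(O)c(CC=C)c2)c(O)c(C(c2cc(Cl)cc(Cl)c2)N2CCCCC2)c1`, carries a further change in the same place: 3,5-dichlorophenyl in place of 4-chlorophenyl on a saturated chain carbon bound to an amine nitrogen in a ring and an aromatic carbon. Going by the values given here, no measured pair shows what moving from one chlorine to two chlorines does, so the single step gives only loose guidance; chlorinated aryl here gave the lower number, and adding a second chlorine in this study has no precedent. A step from compound 2 to compound 3 within the scatter, a number 1 percentage points lower from compound 2 to compound 3 (within the scatter), is therefore expected. Compound 3 is estimated at 44%, within 28% to 60%.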

Compound 3, a percentage reported as inhibition, at one concentration (the size of the read-out at that concentration, not a potency): 87.7%
For compound 3 the middle estimate is 43.7 percentage points below the measured one, outside the stated range (above it).
By their numbers in this assay, from the lowest: compound 2; then compound 1; then compound 3.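

In this assay, this position proves far more responsive than the first step suggested: replacing 4-chlorophenyl with 3,5-dichlorophenyl gives a number 42.7 percentage points higher from compound 2 to compound 3 (beyond the scatter), a large change from a swap that adds a single heavy atom. Replacing 3,4,5-trimethoxyphenyl with 3,5-dichlorophenyl gives a number 31.3 percentage points higher from compound 1 to compound 3 (beyond the scatter), so chlorine on this aryl ring does not go with the lower number in every case: compound 2 sits below compound 1, while compound 3 sits above it. No measurement here explains the jump.

The step changes both the number of chlorines and where they sit, so the compounds shown cannot say which of the two matters. From the compounds shown here alone, it also remains open whether bromine or trifluoromethyl in place of the chlorines would keep the high number.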